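Allyl to propargyl thioether in a cytotoxicity series

This account rests on a few compounds, and the source may have more. Where it says the series, first, only, none or still open, it means among the compounds named here.

Measured in a functional assay on PC-3M cells (Homo sapiens) for cytotoxicity, read by MTT assay, with a stated time of 48 h; a higher number here means a weaker inhibitor, a lower number a stronger inhibitor:
- compound 1 `C=CCSc1nnc(CC)n1N1C(=O)c2ccccc2C1=O` gives > 200000 nM, a limit of the assay
- compound 2 `CCc1nnc(SCC(=O)c2ccc(C)cc2)n1N1C(=O)c2ccccc2C1=O` gives > 200000 nM, a limit of the assay
- compound 3 `C=CCSc1nnc(CCC)n1N1C(=O)c2ccccc2C1=O` gives > 200000 nM, a limit of the assay

Compound 3 therefore stands only at a limit, with no number. The same holds for compound 1 and compound 2 (the limit of > 200000 nM in this assay, at which 3 of the 3 values shown sit), so the step that the two limits leave unreadable from compound 1 to compound 3 and the step that the two limits leave unreadable from compound 1 to compound 2 are both unreadable.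

Compound 4 `C#CCSc1nnc(CCC)n1N1C(=O)c2ccccc2C1=O` is not yet measured. It differs from compound 3 by ethynyl in place of vinyl on a saturated chain carbon bound to a sulfur. Going by the values given here, no measured step speaks to this change, and every value in this assay sits at the limit, so no readable direction can be taken from them.

Compound 4 is expected to give 300000 nM (range 100000 nM to 1000000 nM), most likely reported again as a limit, which corresponds to an expected step that the limit leaves unreadable from compound 3 to compound 4.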

Compound 4, half-maximal inhibitory concentration: > 200000 nM
Compound 4: a limit, no number; the forecaster's own chance of this, stated with the estimate: 85%; the middle value is on the limit's open side.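

The step from allyl to propargyl between compound 3 and compound 4 cannot be read, as both stand only at a limit: the limit of > 200000 nM in this assay, at which 4 of the 4 values shown sit. The compounds shown leave open which structural changes, if any, bring a measurable value in this assay.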